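The source may report more compounds than this note shows. Statements on the series, on what has been measured and on what is new or still open speak of the compounds shown alone.

Measured so far:
compound 1 `C#CCNC(=O)c1ccc(C(CC)(CC)c2ccc(OCC(O)C(C)(C)C)c(C)c2)n1CC`: 240 nM
compound 2 `CCn1c(C(=O)N(C)CCC#N)ccc1C(CC)(CC)c1ccc(OCC(O)C(C)(C)C)c(C)c1`: 1960 nM
compound 3 `C#CC(C)OC(=O)c1ccc(C(CC)(CC)c2ccc(OCC(O)C(C)(C)C)c(C)c2)n1CC`: 200 nM

Compound 3 gives the lowest of the three numbers in an assay on HL-60 cells for agonist activity at vitamin D3 receptor (Homo sapiens), read by microscopy, with a stated time of 96 h; a lower number here means that less compound is needed, a higher number that more compound is needed for the effect; compound 1 sits within the scatter of it (a 1.2-fold lower number from compound 1 to compound 3 (0.08 log units; within the scatter)), and only compound 2 stands clearly apart (a 9.8-fold lower number from compound 2 to compound 3 (0.99 log units; beyond the scatter)). Within the data shown here, the series so far varies only the group on the carbonyl carbon; the change from compound 1 to compound 2 raised the number (an 8.2-fold higher number from compound 1 to compound 2 (0.91 log units; beyond the scatter)).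

Compound 4 `CCn1c(C(=O)Nc2cccc(C(F)(F)F)c2)ccc1C(CC)(CC)c1ccc(OCC(O)C(C)(C)C)c(C)c1` is next: (3-(trifluoromethyl)phenyl)amino in place of (1-methylprop-2-yn-1-yl)oxy on a carbonyl carbon

Among the measured compounds shown here, two steps bear on this. Compound 1, where the carbonyl carbon also bears a nitrogen carrying one hydrogen, differs from compound 3 by a step within the scatter; compound 2, with a nitrogen carrying no hydrogen, lies well higher. For the measured compounds named here, the entering group resembles compound 1 more than compound 2 in this respect, but it is larger and brings a ring, for which there is no precedent. An expected step of a 2.3-fold higher number from compound 3 to compound 4 (0.35 log units; beyond the scatter) therefore carries wide uncertainty. For compound 4 the estimate in this assay is 450 nM, with a range from 120 nM to 1800 nM.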

Compound 4, half-maximal effective concentration: > 50000 nM
Compound 4 gave a limit, no number; the forecaster's own chance of this, stated with the estimate: 5%; at least 110-fold (2.04 log units) between middle value and limit.
By their numbers in this assay, from the lowest: compounds 3 and 1 (each within the scatter of the next); then compound 2. At a limit, above all of these: compound 4.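

In this assay compound 4 gives > 50000 nM as a limit of the assay, not a number. A nitrogen carrying one hydrogen on the carbonyl carbon is no safeguard at this position: an at least 200-fold higher number from compound 1 to compound 4 (2.31 log units; beyond the scatter) follows from 3-(trifluoromethyl)phenyl in place of propargyl on that nitrogen, so the same linkage now carries both a low number and a limit. Among these compounds, the entering group also lies clear of the other two groups, with an at least 250-fold higher number from compound 3 to compound 4 (2.39 log units; beyond the scatter) against (1-methylprop-2-yn-1-yl)oxy and an at least 25-fold higher number from compound 2 to compound 4 (1.40 log units; beyond the scatter) against (2-cyanoethyl)(methyl)amino, so the position is far less forgiving than the earlier compounds suggested.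

The compounds shown leave open whether this step follows from the aromatic ring or from the trifluoromethyl on it; plain phenylamino and cyclohexylamino groups on the carbonyl carbon would separate the two. Also open, from the compounds shown here alone, is how a carboxylic acid would read here.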